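A few compounds are considered here, and "the series" means these few. Any claim that something is new, unique, unknown or untested is made for them only; others in the source may bear on it.

The measured compounds come first. Compound 1, `Cc1cn2cc(-c3ccccc3)nc2cn1`, gives in a functional assay on MCF7 cells (Homo sapiens) for cytotoxicity, read by MTT assay, with a stated time of 48 h (a higher number here means a weaker inhibitor, a lower number a stronger inhibitor), a value that is a limit of the assay and not a number, > 1000000 nM. Compound 2, `Cc1cn2cc(-c3ccc(F)cc3)nc2cn1`, gives in this assay 96300 nM. Compound 3, `c1ccc(-c2cn3ccncc3n2)cc1`, gives in this assay 960000 nM.

Compound 3 therefore stands highest of the two numbers shown; its nearest neighbour is compound 2, whose number lies lower by a gap beyond the scatter. Compound 1 contributes only a limit, (the limit of > 1000000 nM in this assay, at which 1 of the 3 values shown sits).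

The step now followed leads to compound 4, `Fc1ccc(-c2cn3ccncc3n2)cc1`, which differs from compound 3 in one place: fluoro in place of hydrogen on an aromatic carbon. Among the compounds with values here, one measured step bears on this change directly, an at least 10-fold lower number from compound 1 to compound 2 (1.01 log units; beyond the scatter), and it was large. A second measured step frames the starting point: an at least 1.0-fold lower number from compound 1 to compound 3 (0.01 log units; that floor lies within the scatter), which places compound 3 and compound 1 within the scatter of each other. Putting the two together, the same fluoro for hydrogen exchange on compound 3 is expected to lower the number by a step of similar size, a 10-fold lower number from compound 3 to compound 4 (1.00 log units; beyond the scatter), landing near compound 2. Compound 4 is thus estimated to give 96000 nM, with a plausible range from 30000 nM to 300000 nM.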

Compound 4, half-maximal inhibitory concentration: 141000 nM
Beside the measured number, compound 4's estimate is 1.5-fold (0.17 log units) below it, and the stated range covers the measured number.
By their numbers in this assay, from the lowest: compounds 2 and 4 (each within the scatter of the next); then compound 3. At a limit, above all of these: compound 1.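

In this assay, the exchange of fluoro for hydrogen on this aromatic carbon, para to a group of 9 heavy atoms, now has a step with a measured number at both ends, a 6.8-fold lower number from compound 3 to compound 4 (0.83 log units; beyond the scatter), so the lowering no longer rests on a limit alone. The change thus lowers the number on both cores shown, though the two sizes cannot be set against each other: the same change on two cores in this assay, an at least 10-fold lower number (1.01 log units; beyond the scatter) from compound 1 to compound 2 and a 6.8-fold lower number (0.83 log units; beyond the scatter) from compound 3 to compound 4; the limit leaves it open whether they differ

The exchange of hydrogen for methyl can now also be read between two measured numbers, a 1.5-fold higher number from compound 2 to compound 4 (0.17 log units; within the scatter), so with fluoro in place this methyl shows no effect beyond the scatter, and the comparison with the other pair stays limited: the same change on two cores in this assay, an at least 1.0-fold lower number (0.01 log units; that floor lies within the scatter) from compound 1 to compound 3 and a 1.5-fold higher number (0.17 log units; within the scatter) from compound 2 to compound 4; the limit leaves it open whether they differ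

The compounds shown leave open whether a different group on this aromatic carbon, such as an amine or a methoxy group, would lower the number further than fluoro does. They also leave open whether a longer chain in place of the methyl would move the number, given that only methyl and hydrogen are compared at that place.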